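The source may hold more compounds than are shown below. What is called first, only, known or untested is meant among the compounds shown, and "the series" means these compounds.

Compound 1 `CC(C)C(c1ccc(-c2ccc3cccc(F)c3c2)[nH]c1=O)N1CCN/C1=N\C#N`: 38 nM
Compound 2 `Cc1nc(C(c2ccc(-c3ccc4cccc(F)c4c3)[nH]c2=O)C(C)C)[nH]c1C`: 50 nM

In a functional assay on CHO cells for antagonist activity at prostaglandin E2 receptor EP3 subtype (Homo sapiens), read by cAMP accumulation (on this read-out lower numbers stand for stronger inhibition and higher numbers for weaker inhibition), compound 2 gives 50 nM, and compound 1 gives 38 nM, so the two measured values lie within the scatter of each other; the step of a 1.3-fold higher number from compound 1 to compound 2 (0.12 log units; within the scatter) shows that exchanging one five-membered ring for another at this position did not move the read-out beyond the scatter. Compound 3 `CC(C)C(Cc1noc(=O)[nH]1)c1ccc(-c2ccc3cccc(F)c3c2)[nH]c1=O` is the next step from compound 2, with a group of 7 heavy atoms (3 carbon, 2 nitrogen, 2 oxygen; one five-membered aromatic ring with 3 hetero atoms) in place of a group of 7 heavy atoms (5 carbon, 2 nitrogen; one five-membered aromatic ring with 2 hetero atoms), on a saturated chain carbon bound to an aromatic carbon and a saturated chain carbon. For the measured compounds named here, the only measured step that bears on it is that from compound 1 to compound 2, which also exchanged the ring group at the same saturated chain carbon and stayed within the scatter. On that basis no step beyond the scatter is expected in this assay, in either direction, for the step of no change at the digits printed from compound 2 to compound 3 (within the scatter). Compound 3 is therefore estimated at 50 nM, with a range from 20 nM to 130 nM.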

Compound 3, half-maximal inhibitory concentration: 70 nM
For compound 3 the middle estimate is 1.4-fold (0.15 log units) below the measured one; the measured number falls inside the stated range.
By their numbers in this assay, from the lowest: compounds 1, 2 and 3 (each within the scatter of the next).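

In this assay, replacing the 4,5-dimethyl-1H-imidazol-2-yl group with the group bearing a five-membered aromatic ring with 3 hetero atoms gives a 1.4-fold higher number from compound 2 to compound 3 (0.15 log units; within the scatter), and replacing the non-aromatic ring group of compound 1 with that same group gives a 1.8-fold higher number from compound 1 to compound 3 (0.27 log units; within the scatter). On a saturated chain carbon bound to an aromatic carbon and a saturated chain carbon, three different ring groups now read within the scatter of one another, and this tolerance extends to a group with oxygen atoms, 3 hydrogen-bond acceptors and a double bond outside aromatic rings. No measurement here offers an explanation for this.

The compounds shown leave open whether this tolerance holds without a five-membered ring. A carboxylic acid or an amine on this carbon would test that.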